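Replacing One Amide Side Group in a Cell Assay

A few compounds are considered here, and "the series" means these few. Any claim that something is new, unique, unknown or untested is made for them only; others in the source may bear on it.

In a functional assay on BGC-823 cells (Homo sapiens) for inhibition, read by sulforhodamine B assay, with a stated time of 3 days (a lower number here means a stronger inhibitor, a higher number a weaker inhibitor), compound 1 (`O=C1Nc2ccc(F)cc2/C1=C\C(=O)c1ccc(O)cc1F`) gives 6120 nM while compound 2 (`O=C1Nc2ccc(F)cc2/C1=C\C(=O)c1ccc(C2CCCCC2)cc1`) gives 4450 nM on the same cells. Compound 3 (`CN1CCN(c2cccc(N/C=C3\C(=O)Nc4ccc(NC(=O)c5cccc(F)c5)cc43)c2)CC1`) gives 8500 nM and lies within the usual scatter of both, so these three cannot be ranked. Compound 4 (`CC(C)CC(=O)Nc1ccc2c(c1)/C(=C/Nc1cccc(N3CCN(C)CC3)c1)C(=O)N2`) has not yet been measured. It differs from compound 3 by one change (isobutyl in place of 3-fluorophenyl on a carbonyl carbon) that puts isobutyl in place of 3-fluorophenyl on a carbonyl carbon. For the measured compounds named here, no measured pair shows a change of this kind, so the data offer no direct guide. The expected step of a 1.1-fold higher number from compound 3 to compound 4 (0.02 log units; within the scatter) stays within the scatter, with no clear direction. Compound 4 is estimated at 9000 nM within an expected range from 3500 nM to 25000 nM once tested.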

Compound 4, half-maximal inhibitory concentration: 6080 nM
The estimate for compound 4 lay 1.5-fold (0.17 log units) above the measured number; low and high end bracket the measured number.
By their numbers in this assay, from the lowest: compounds 2, 4, 1 and 3 (each within the scatter of the next).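

In this assay, isobutyl in place of 3-fluorophenyl on a carbonyl carbon gives a 1.4-fold lower number from compound 3 to compound 4 (0.15 log units; within the scatter). For the compounds shown here, this is the first pair here that differs in one place, and it shows that, for these two compounds, the aromatic ring and its fluorine can be exchanged for an open carbon chain without a change beyond the scatter. Nothing available explains this result.

On these data alone, it remains open whether an amine, a carboxylic acid or a longer chain on this carbonyl carbon would shift the number beyond the scatter. As far as these compounds go, the same exchange on a different core also remains untested here.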